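This account rests on a few compounds, and the source may have more. Where it says the series, first, only, none or still open, it means among the compounds named here.

Three compounds share one core and differ only in the group that sits on an aromatic carbon of the six-membered aromatic ring with one nitrogen, next to the ring nitrogen. Compound 1 `CC1CCCN1c1ccc2cc(NC(=O)CCc3ccc(C(F)(F)F)cc3)ccc2n1` carries 2-methylpyrrolidin-1-yl and gives 5 nM in an assay on isolated protein for displacement of a labelled ligand from melanin-concentrating hormone receptor 1 (Homo sapiens); a higher number here means a weaker inhibitor, a lower number a stronger inhibitor. Compound 2 `CC1CCN(c2ccc3cc(NC(=O)CCc4ccc(C(F)(F)F)cc4)ccc3n2)C1` carries 3-methylpyrrolidin-1-yl and gives 2 nM in this assay. Compound 3 `CN(C)c1ccc2cc(NC(=O)CCc3ccc(C(F)(F)F)cc3)ccc2n1` carries dimethylamino and gives 13 nM in this assay, the highest of the three numbers; the steps of a 2.6-fold higher number from compound 1 to compound 3 (0.41 log units; beyond the scatter) and a 6.5-fold higher number from compound 2 to compound 3 (0.81 log units; beyond the scatter) both run upward, so compound 3 is the weakest inhibitor of the three. Compound 4 `NC1CCN(c2ccc3cc(NC(=O)CCc4ccc(C(F)(F)F)cc4)ccc3n2)C1` arises from compound 3 by the change (3-aminopyrrolidin-1-yl in place of dimethylamino on an aromatic carbon). Read backward, the step of a 6.5-fold higher number from compound 2 to compound 3 (0.81 log units; beyond the scatter) shows that trading dimethylamino for a five-membered ring bearing a methyl lowers the number substantially. Among the compounds with values here, compound 4 brings in the same ring, but with an amino group in place of that methyl, and no measured pair shows what this swap does. A lowering is therefore expected, estimated as a 2.6-fold lower number from compound 3 to compound 4 (0.41 log units; beyond the scatter), held with less confidence than a measured step. Compound 4 is thus expected to give about 5 nM in this assay, most likely between 1.5 nM and 30 nM.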

Compound 4, half-maximal inhibitory concentration: 12 nM
The estimate for compound 4 lay 2.4-fold (0.38 log units) below the measured number, and the stated range covers the measured number.
By their numbers in this assay, from the lowest: compound 2; then compound 1; then compounds 4 and 3 (each within the scatter of the next).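

In this assay, putting a five-membered ring on this aromatic carbon does not lower the number by itself: the step of a 1.1-fold lower number from compound 3 to compound 4 (0.03 log units; within the scatter) leaves 3-aminopyrrolidin-1-yl level with dimethylamino. What the ring carries makes the difference, as the step of a 6.0-fold higher number from compound 2 to compound 4 (0.78 log units; beyond the scatter) exchanges only methyl for amino on a saturated ring carbon and loses the advantage held by 3-methylpyrrolidin-1-yl. The step of a 2.4-fold higher number from compound 1 to compound 4 (0.38 log units; beyond the scatter) places 3-aminopyrrolidin-1-yl behind 2-methylpyrrolidin-1-yl too, so both methyl-bearing rings give lower numbers than the amino-bearing ring.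

Nothing available explains why amino and methyl differ on this ring. As far as these compounds go, it also remains open where an unsubstituted pyrrolidin-1-yl or a hydroxyl on that same ring carbon would fall relative to the methyl and amino rings.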